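Swapping a propyl for an ethoxycarbonyl on a sulfur-bearing chain

The source may report more compounds than this note shows. Statements on the series, on what has been measured and on what is new or still open speak of the compounds shown alone.

Three compounds share one core and differ only in the chain attached to a sulfur. Compound 1 `O=C(O)Cn1c(SCCCOc2ccccc2)nc2ccccc21` gives 786 nM in an assay on HEK293 cells for displacement of a labelled ligand from prostaglandin D2 receptor 2 (Homo sapiens); on this read-out lower numbers stand for stronger inhibition and higher numbers for weaker inhibition. Compound 2 `O=C(O)Cn1c(SCCNc2ccccc2)nc2ccccc21` gives 7690 nM in this assay, and compound 3 `CCCCCSc1nc2ccccc2n1CC(=O)O` gives 1240 nM. Among these three numbers compound 3 stands second highest: its gap to compound 1 lies within the scatter, while a 6.2-fold lower number from compound 2 to compound 3 (0.79 log units; beyond the scatter). The other step, a 9.8-fold higher number from compound 1 to compound 2 (0.99 log units; beyond the scatter), shows that exchanging the group at this place can move the number to a modest degree in either direction.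

Compound 4 `CCOC(=O)CCSc1nc2ccccc2n1CC(=O)O` has not yet been measured. It arises from compound 3 through (ethoxycarbonyl in place of propyl on a saturated chain carbon, two bonds along the chain from a sulfur). Among the compounds with values here, no measured step replaces a propyl with an ethoxycarbonyl, so the two steps above are the only guide; both are modest in size, and they involve groups with a ring, which the incoming group lacks. The expectation is therefore a modest shift with no firm direction, leaning slightly toward a higher number, expressed as a 2.0-fold higher number from compound 3 to compound 4 (0.30 log units; within the scatter). Compound 4 is estimated to give 2500 nM in this assay, within a range from 800 nM to 8000 nM.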

Compound 4, half-maximal inhibitory concentration: 11400 nM
For compound 4 the middle estimate is 4.6-fold (0.66 log units) below the measured one; measured number above the stated range.
By their numbers in this assay, from the lowest: compounds 1 and 3 (each within the scatter of the next); then compounds 2 and 4 (each within the scatter of the next).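

In this assay, within the data shown here, there is a 9.2-fold higher number from compound 3 to compound 4 (0.96 log units; beyond the scatter), so a group without a ring can also shift the number beyond the scatter at this place, which the earlier steps, all of them involving a ring, could not show. Two very different groups also give numbers that cannot be told apart here, with a 1.5-fold higher number from compound 2 to compound 4 (0.17 log units; within the scatter), so the anilino and ethoxycarbonyl chains read alike despite their different atoms. Among these compounds, the widest gap in the set is now a 15-fold higher number from compound 1 to compound 4 (1.16 log units; beyond the scatter), the only large step so far, and it places the ethoxycarbonyl chain well apart from the phenoxymethyl chain.

No measurement at hand says why the ethoxycarbonyl chain and the propyl chain differ in this way. Still open, from the compounds shown here alone, is how a carboxylic acid or an amine in place of the ethoxycarbonyl would read at this place, and whether a longer chain carrying the ethoxycarbonyl would move the number in this assay back toward that of the pentyl chain of compound 3.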